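Trimming the ester from compound 2

This account rests on a few compounds, and the source may have more. Where it says the series, first, only, none or still open, it means among the compounds named here.

Measured compounds:
compound 1, `Cc1ccc(S(=O)(=O)c2cnc3cc(F)ccc3c2N2CCC(C)CC2)cc1C` — 90%
compound 2, `CCOC(=O)C1CCN(c2c(S(=O)(=O)c3ccccc3)cnc3ccccc23)CC1` — 33%
compound 3, `CC1CCN(c2c(S(=O)(=O)c3cc(F)cc(F)c3)cnc3c(F)cccc23)CC1` — 9%

All three were tested in an assay on isolated protein for displacement of a labelled ligand from metabotropic glutamate receptor 5 (Homo sapiens), with a stated time of 60 min, tested at 1 uM; on this read-out higher numbers stand for more inhibition at the one concentration tested (going by the name of the read-out) and lower numbers for less inhibition. Compound 2 stands second highest of the three numbers; its nearest neighbour is compound 3, whose value lies lower by more than the scatter, while compound 1 lies further above it, also beyond the scatter. Compound 4, `O=S(=O)(c1ccccc1)c1cnc2ccccc2c1N1CCCCC1`, has not been measured. It differs from compound 2 in one place: hydrogen in place of ethoxycarbonyl on a saturated ring carbon. Among the measured compounds shown here, no pair of measured compounds isolates this change, and compounds 1 and 3 show values far apart from each other, so the measured set gives little guidance. The step of a number 7 percentage points higher from compound 2 to compound 4 (within the scatter) is expected to be small, likely within the scatter. Compound 4 is therefore estimated at 40%, with a range from 10% to 75%.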

Compound 4, a percentage reported as inhibition, at one concentration (the size of the read-out at that concentration, not a potency): 71.4%
Compound 4: middle estimate off by 31.4 percentage points, on the low side; low and high end bracket the measured number.
By their numbers in this assay, from the lowest: compound 3; then compound 2; then compound 4; then compound 1.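

Taking ethoxycarbonyl off this saturated ring carbon is not a neutral trim: in this assay the change gives a number 38.4 percentage points higher from compound 2 to compound 4 (beyond the scatter). Among the compounds shown here, as the first comparison of compounds differing only in one place, it shows that this position, three ring bonds from the ring nitrogen, responds strongly to what it carries. Nothing measured here explains the size of this step. On these data alone, whether a carboxylic acid or an amine on the same carbon would read more like ethoxycarbonyl or more like hydrogen stays open. Also open, as far as these compounds go, is how the methyl on compound 1 and compound 3 compares with hydrogen on a shared core.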